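The source may report more compounds than this note shows. Statements on the series, on what has been measured and on what is new or still open speak of the compounds shown alone.

Compound 1 `CCNCCCOc1ccc2cc(NC(=O)c3ccc(O)c(CC=C(C)C)c3)c(=O)oc2c1C` gives 720 nM in a functional assay on SK-BR-3 cells (Homo sapiens) for antiproliferative activity (a lower number here means a stronger inhibitor, a higher number a weaker inhibitor), the second highest of the three numbers measured. Compound 2 `CC(C)=CCc1cc(C(=O)Nc2cc3ccc(OCCCNC(C)(C)C)c(C)c3oc2=O)ccc1O` gives 660 nM; the step of a 1.1-fold lower number from compound 1 to compound 2 (0.04 log units; within the scatter) is within the scatter. Compound 3 `CC(C)=CCc1cc(C(=O)Nc2cc3ccc(OCCCNCC(N)=O)c(C)c3oc2=O)ccc1O` gives 2290 nM; the steps of a 3.2-fold higher number from compound 1 to compound 3 (0.50 log units; beyond the scatter) and a 3.5-fold higher number from compound 2 to compound 3 (0.54 log units; beyond the scatter) are both modest losses. Compound 4 `CC(C)=CCc1cc(C(=O)Nc2cc3ccc(OCCCNCCO)c(C)c3oc2=O)ccc1O` is not yet measured in this assay. Its difference from compound 1 is hydroxy in place of hydrogen on a saturated chain carbon, two bonds along the chain from an amine nitrogen. Going by the values given here, no measured step makes exactly this change; the closest comparison is compound 3, where carbamoyl in place of methyl on a saturated chain carbon bound to an amine nitrogen cost potency. A smaller loss than that is expected here, giving a 1.7-fold higher number from compound 1 to compound 4 (0.22 log units; within the scatter). Compound 4 is therefore estimated at 1200 nM, with a range from 600 nM to 2500 nM.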

Compound 4, half-maximal inhibitory concentration: 610 nM
For compound 4 the middle estimate is 2.0-fold (0.29 log units) above the measured one; the range from low to high includes it.
By their numbers in this assay, from the lowest: compounds 4, 2 and 1 (each within the scatter of the next); then compound 3.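

In this assay, hydroxy in place of hydrogen on a saturated chain carbon, two bonds along the chain from an amine nitrogen, is tolerated: a 1.2-fold lower number from compound 1 to compound 4 (0.07 log units; within the scatter). Exchanging tert-butyl for 2-hydroxyethyl on the amine nitrogen also leaves the read-out unresolved, a 1.1-fold lower number from compound 2 to compound 4 (0.03 log units; within the scatter), so ethyl, tert-butyl and 2-hydroxyethyl cannot be separated here. Only the carbamoylmethyl substituent stands apart, a 3.8-fold lower number from compound 3 to compound 4 (0.57 log units; beyond the scatter), so the loss belongs to that group and not to every oxygen-bearing substituent in this set. No supporting data explain this difference. Going by these compounds, whether a carboxylic acid or a longer hydroxyalkyl chain on this nitrogen would stay in the same range remains open.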